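This account rests on a few compounds, and the source may have more. Where it says the series, first, only, none or still open, it means among the compounds named here.

Compound 1 `C=CC(=O)Nc1cccc(Nc2ncnc(Nc3ccc(C(=O)N4CCCCC4)cc3)n2)c1`: 6140 nM in a functional assay on Ramos cells (Homo sapiens) for antiproliferative activity, read by CCK-8 assay, with a stated time of 24 h; a higher number here means a weaker inhibitor, a lower number a stronger inhibitor
Compound 2 `C=CC(=O)Nc1cccc(Nc2nc(Cl)nc(Nc3ccc(OCCOC)cc3)n2)c1`: "not determined" (no result reported)
Compound 3 `C=CC(=O)N1CCc2ccc(Nc3ncnc(Nc4ccc(C(=O)N5CCCCC5)cc4)n3)cc21`: "not determined" (no result reported)

Compound 1 is the only one of the three with a number in this assay. Compound 2 and compound 3 each carry no result in this assay, so compound 1 stands alone and cannot be ranked against anything; its value simply marks where the series begins.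

Compound 4 `C=CC(=O)Nc1cccc(Nc2ncnc(Nc3ccc(C(=O)Nc4ccc(C)cn4)cc3)n2)c1` is the compound still to be measured. It differs from compound 1 in one place: (5-methylpyridin-2-yl)amino in place of piperidin-1-yl on a carbonyl carbon. The rest of the molecule, including the acrylamide and the shared core of compound 1, is unchanged.

Within the data shown here, no pair of measured compounds differs in one place, so there is no step to lean on, and the effect of trading the piperidine amide for the pyridinyl amide has not been seen. The expectation therefore rests on compound 1 alone, and the step from compound 1 to compound 4 is estimated as a 1.5-fold lower number from compound 1 to compound 4 (0.19 log units; within the scatter) in this assay, a shift that may well lie within the scatter. For compound 4 the expected value in this assay is 4000 nM, with a range from 1200 nM to 15000 nM.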

Compound 4, half-maximal inhibitory concentration: > 100000 nM
Compound 4 ended at the assay's limit (the forecaster's own chance of this, stated with the estimate: 10%); at least 25-fold (1.39 log units) between middle value and limit.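

In this assay compound 4 ended at a limit of the measurement and not at a number: the limit of > 100000 nM in this assay, at which 1 of the 4 values shown sits. Placing (5-methylpyridin-2-yl)amino instead of piperidin-1-yl on the carbonyl carbon gives an at least 16-fold higher number from compound 1 to compound 4 (1.21 log units; beyond the scatter), the first step in this series that can be read, and it is a large one in the direction of a weaker inhibitor. The acrylamide and the shared core are the same in both compounds, so the loss is tied to this one place, which shows that the group on this carbonyl carbon is not a free choice and that a swap here can take away what little antiproliferative activity the piperidine amide has.

The swap changes several things at once, bringing in an aromatic ring, a methyl group and an amide hydrogen, and a single step cannot separate them or say why the activity falls. A morpholin-4-yl ring or a small dimethylamino group on the same carbonyl carbon would show whether the piperidine ring itself matters or whether a tertiary amide of any kind is enough.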